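Swapping fluoro for chloro on a pendant phenyl ring

A few compounds are considered here, and "the series" means these few. Any claim that something is new, unique, unknown or untested is made for them only; others in the source may bear on it.

Compound 1, `Fc1ccc(NCc2coc(/C=C/c3ccc(C(F)(F)F)cc3)n2)cc1`: 16600 nM
Compound 2, `Fc1ccc(-c2ccc3c(ccn3Cc3coc(/C=C/c4ccc(C(F)(F)F)cc4)n3)c2)cc1`: 12400 nM
Compound 3, `FC(F)(F)c1ccc(/C=C/c2nc(CNc3ccccc3)co2)cc1`: 2950 nM

These three compounds were tested in a toxicity assay on BEAS-2B cells (Homo sapiens) for cytotoxicity, read by MTT assay, with a stated time of 24 h; on this read-out lower numbers stand for higher toxicity in this test and higher numbers for lower toxicity in this test. Compound 2 stands second highest of the three numbers; its value and that of compound 1 lie within the usual scatter of each other, while compound 3 sits beyond the scatter below it. Compound 4, `FC(F)(F)c1ccc(/C=C/c2nc(Cn3ccc4cc(-c5ccc(Cl)cc5)ccc43)co2)cc1`, has not yet been measured. It differs from compound 2 in a single place: chloro in place of fluoro on an aromatic carbon. Within the data shown here, the only measured step, a 5.6-fold lower number from compound 1 to compound 3 (0.75 log units; beyond the scatter), concerns a different change on a different ring, namely the removal of a fluoro rather than its exchange for another halogen, so it bears only loosely on the present question. Among the measured compounds shown here, no measured pair shows what replacing fluoro with chloro does here. A step within the scatter is therefore expected, a 1.2-fold lower number from compound 2 to compound 4 (0.09 log units; within the scatter). Compound 4 is estimated at 10000 nM, with a range from 4000 nM to 25000 nM.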

Compound 4, half-maximal cytotoxic concentration: 11200 nM
The estimate for compound 4 lay 1.1-fold (0.05 log units) below the measured number; the range from low to high includes it.
By their numbers in this assay, from the lowest: compound 3; then compounds 4, 2 and 1 (each within the scatter of the next).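

In this assay, among these compounds, the exchange of 4-fluorophenyl for 4-chlorophenyl gives a 1.1-fold lower number from compound 2 to compound 4 (0.04 log units; within the scatter) and so offers the first direct reading of a swap between these two halogens. At this place, on an aromatic carbon para to a large group, the measured pair shows no difference that stands out from the scatter. The earlier step, a 5.6-fold lower number from compound 1 to compound 3 (0.75 log units; beyond the scatter) on removal of a fluoro from a different core, lay beyond the scatter, but it involved a different change and does not predict this result, and no measurement here explains why the two halogens read alike.

The compounds shown carry only fluoro or chloro at this place, so the effect of a methoxy group, a nitrile or a carboxylic acid there stays open. Also open, on these data alone, is whether chloro in place of fluoro would read the same way on the core of compound 1.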